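Anilino Variation on a Shared Core: Compound 4 Expected

A few compounds are considered here, and "the series" means these few. Any claim that something is new, unique, unknown or untested is made for them only; others in the source may bear on it.

The measured compounds:
compound 1, `CC(C)c1ccc(-c2nc(SCc3cn(CC(=O)NC(=O)Nc4ccccn4)nn3)nc(Nc3ccc(Cl)cc3)c2C#N)cc1`: > 64000 nM
compound 2, `CC(C)c1ccc(-c2nc(SCc3cn(CC(=O)NC(=O)Nc4ccccn4)nn3)nc(Nc3cccc(Cl)c3)c2C#N)cc1`: > 64000 nM
compound 3, `CC(C)c1ccc(-c2nc(SCc3cn(CC(=O)NC(=O)Nc4ccccn4)nn3)nc(Nc3cccc([N+](=O)[O-])c3)c2C#N)cc1`: > 64000 nM

In a functional assay on MGC-803 cells (Homo sapiens) for inhibition, read by MTT assay, with a stated time of 72 h (on this read-out higher numbers stand for weaker inhibition and lower numbers for stronger inhibition), compound 1 gives > 64000 nM, which is a limit of the assay and not a number. Compound 2 gives > 64000 nM, again a limit. Compound 3 gives > 64000 nM, also a limit; all three values shown sit at the same limit (the limit of > 64000 nM in this assay, at which 3 of the 3 values shown sit). Compound 3 therefore stands nowhere distinguishable from compound 1 or compound 2.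

Compound 4, `CC(C)c1ccc(-c2nc(SCc3cn(CC(=O)NC(=O)Nc4ccccn4)nn3)nc(Nc3ccccc3F)c2C#N)cc1`, differs from compound 3 by 2-fluorophenyl in place of 3-nitrophenyl on a nitrogen on an aromatic ring. Among the compounds with values here, the steps that bear on this change are a step that the two limits leave unreadable from compound 1 to compound 2, a step that the two limits leave unreadable from compound 1 to compound 3 and a step that the two limits leave unreadable from compound 2 to compound 3; each is unreadable in size, since both ends are limits. Within the data shown here, no measured step gives a readable direction for a change on this nitrogen. The expected step of a number no higher from compound 3 to compound 4 (the limit leaves the size open) is therefore none beyond the scatter, and compound 4 is most likely to be reported as a limit as well. The estimate for compound 4 is 64000 nM, ranging from 20000 nM to 150000 nM.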

Compound 4, half-maximal inhibitory concentration: > 64000 nM
Compound 4: no number, only a limit; the forecaster's own chance of this, stated with the estimate: 80%; the middle value sits exactly at the limit.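

No new step can be read between compound 4 and compound 1, compound 2 or compound 3, because each of the four values is a limit and not a number: the limit of > 64000 nM in this assay, at which 4 of the 4 values shown sit.

The compounds shown leave open how strongly any of them inhibits, and whether any change of the group on this nitrogen shifts the read-out at all.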